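A few compounds are considered here, and "the series" means these few. Any claim that something is new, unique, unknown or untested is made for them only; others in the source may bear on it.

Measured compounds, in a functional assay on A-375 cells (Homo sapiens) for antiproliferative activity, read by MTT assay, with a stated time of 24 h, tested at 33.33 ug/mL; a higher number here means a stronger effect of the compound at the concentration tested, a lower number a weaker effect:

Compound 1, `Cc1ccc2nc(C(=O)Nc3c(F)cc(-c4cccc(F)c4)cc3F)c(C)c(O)c2c1`: 26.5%
Compound 2, `CCc1ccc2nc(C(=O)Nc3c(F)cc(-c4cccc(F)c4)cc3F)c(C)c(O)c2c1`: 28.4%
Compound 3, `Cc1c(C(=O)Nc2c(F)cc(-c3cccc(F)c3)cc2F)nc2ccc(OC(F)(F)F)cc2c1O`: 12.3%

Compound 3 gives the lowest of the three numbers. The step of a number 14.2 percentage points lower from compound 1 to compound 3 (beyond the scatter) and the step of a number 16.1 percentage points lower from compound 2 to compound 3 (beyond the scatter) are both beyond the scatter, so compound 3 sits clearly under compounds 1 and 2, while the step of a number 1.9 percentage points higher from compound 1 to compound 2 (within the scatter) is within the scatter and separates nothing.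

Compound 4, `Cc1c(C(=O)Nc2c(F)cc(-c3cccc(F)c3)cc2F)nc2ccc(C(F)(F)F)cc2c1O`, differs from compound 3 only at one aromatic carbon of the shared core: trifluoromethyl in place of trifluoromethoxy on an aromatic carbon.

Going by the values given here, no measured step exchanges trifluoromethyl for trifluoromethoxy. The two steps that touch this aromatic carbon, a number 14.2 percentage points lower from compound 1 to compound 3 (beyond the scatter) and a number 16.1 percentage points lower from compound 2 to compound 3 (beyond the scatter), both exchange an alkyl group for trifluoromethoxy and both are modest and downward; they tell nothing about replacing trifluoromethoxy with trifluoromethyl. Among the compounds with values here, with no bearing step, no move beyond the scatter is expected in this assay for compound 4, and the estimate is therefore anchored on compound 3 with a wide range.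

Compound 4 is expected to give 16% in this assay, between 6% and 28%.

The expected step of a number 3.7 percentage points higher from compound 3 to compound 4 (within the scatter) is within the scatter.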

Compound 4, a percentage reported as inhibition, at one concentration (the size of the read-out at that concentration, not a potency): 61.3%
Beside the measured number, compound 4's estimate is 45.3 percentage points below it, outside the stated range (above it).
By their numbers in this assay, from the lowest: compound 3; then compounds 1 and 2 (each within the scatter of the next); then compound 4.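

Notes on this position: in this assay, the substituent on this aromatic carbon of the shared core can move the read-out by a large margin, and the exchange of trifluoromethoxy for trifluoromethyl gives a number 49 percentage points higher from compound 3 to compound 4 (beyond the scatter). Trifluoromethyl also stands clear of both alkyl groups, with a number 34.8 percentage points higher from compound 1 to compound 4 (beyond the scatter) and a number 32.9 percentage points higher from compound 2 to compound 4 (beyond the scatter), so the position is no longer described only by the modest downward steps from alkyl to trifluoromethoxy. The three fluorine atoms alone do not set the outcome, as trifluoromethoxy and trifluoromethyl each carry them, yet compound 3 lies under compounds 1 and 2 and compound 4 lies above them.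

No measurement here accounts for the size of this step. Still open, on these data alone, is whether the higher number belongs to trifluoromethyl alone or extends to other groups at this carbon, such as chlorine, a nitrile, an amine or a carboxylic acid, and whether it would persist across a range of concentrations, since each compound is represented here by a single read-out at one concentration.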